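Estimating a carbamate analogue of a pyrazole EP1 ligand

This account rests on a few compounds, and the source may have more. Where it says the series, first, only, none or still open, it means among the compounds named here.

Measured compounds:
compound 1 `CNC(=O)c1cc(C)n(Cc2cc(Cl)ccc2OCc2ccccc2)n1` gives 100 nM
compound 2 `Cc1cc(NC(=O)c2ccccc2)nn1Cc1cc(Cl)ccc1OCc1ccccc1` gives 15.9 nM

Both compounds were tested in an assay on CHO-K1 cells for displacement of a labelled ligand from prostaglandin E2 receptor EP1 subtype (Homo sapiens); on this read-out lower numbers stand for stronger inhibition and higher numbers for weaker inhibition. Among the measured compounds shown here, of the two numbers measured, compound 1 shows the highest, and its nearest neighbour is compound 2, the only other compound measured: a 6.3-fold lower number from compound 1 to compound 2 (0.80 log units; beyond the scatter). That step swapped methylcarbamoyl for benzamido on an aromatic carbon of the shared core, a modest change that moved the number well beyond the scatter.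

Compound 3 `Cc1cc(NC(=O)OCC(C)C)nn1Cc1cc(Cl)ccc1OCc1ccccc1` has not yet been measured. Compared with compound 1, it shows ((isobutoxycarbonyl)amino in place of methylcarbamoyl on an aromatic carbon). Like the step to compound 2, this change puts a hydrogen-bond donor nitrogen on the ring carbon in place of the carbonyl carbon of methylcarbamoyl, so the step from compound 1 to compound 2 is the only relevant guide, and it points toward a lower number. On that basis compound 3 is expected to give 25 nM, within 8 nM to 80 nM, that is, an expected step of a 4.0-fold lower number from compound 1 to compound 3 (0.60 log units; beyond the scatter).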

Compound 3, half-maximal inhibitory concentration: 25.1 nM
For compound 3 the middle estimate is 1.0-fold (0.00 log units) below the measured one; the measured number falls inside the stated range.
By their numbers in this assay, from the lowest: compounds 2 and 3 (each within the scatter of the next); then compound 1.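

In this assay the lower number seen with benzamido does not depend on its phenyl ring, as (isobutoxycarbonyl)amino on the same aromatic carbon also gives a 4.0-fold lower number from compound 1 to compound 3 (0.60 log units; beyond the scatter) and the swap of phenyl for isobutoxy on the carbonyl carbon gives a 1.6-fold higher number from compound 2 to compound 3 (0.20 log units; within the scatter). Among these compounds, then, a ring and a branched chain on that carbonyl cannot be told apart, and both stand clear of methylcarbamoyl. No measurement given here bears on the reason for this.

As far as these compounds go, what stays open is whether the lower numbers follow from the nitrogen now bound to the ring carbon or from the larger group that comes with it. Also open, from the compounds shown here alone, is how a simple amine, a carboxylic acid or an unbranched butoxy chain would read at this position.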